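The source may hold more compounds than are shown below. What is called first, only, known or untested is meant among the compounds shown, and "the series" means these compounds.

Three ureas built on the same core have been tested in an assay on microsomes from intestine for inhibition of acyl-CoA:cholesterol acyltransferase (Oryctolagus cuniculus); a lower number here means a stronger inhibitor, a higher number a weaker inhibitor. Compound 1 `Cc1ccccc1NC(=O)NCC1(c2ccccc2)CCCCC1` gives 640 nM. Compound 2 `Cc1cccc(NC(=O)NCC2(c3ccccc3)CCCCC2)c1` gives 2800 nM. Compound 3 `CC(C)c1ccc(NC(=O)NCC2(c3ccccc3)CCCCC2)cc1` gives 1500 nM, the second highest of the three numbers, within the scatter of compound 2 and clearly weaker than compound 1. Compound 4 `O=C(NCC1(c2ccccc2)CCCCC1)Nc1ccc(Cl)cc1` differs from compound 3 by chloro in place of isopropyl on an aromatic carbon. Going by the values given here, no measured step exchanges one group for another at this position; the only measured step, a 4.4-fold higher number from compound 1 to compound 2 (0.64 log units; beyond the scatter), kept the same methyl group and gave a modest shift. A change of similar or smaller size is therefore expected here, probably none beyond the scatter, and the step of a 1.3-fold lower number from compound 3 to compound 4 (0.10 log units; within the scatter) is the estimate. Compound 4 is expected to give about 1200 nM, between 400 nM and 3600 nM.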

Compound 4, half-maximal inhibitory concentration: 2200 nM
Estimate against measurement, compound 4: 1.8-fold (0.26 log units) below; measured number inside the range.
By their numbers in this assay, from the lowest: compound 1; then compounds 3, 4 and 2 (each within the scatter of the next).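

Swapping isopropyl for chloro, para to a large group, removes heavy atoms yet gives no clear change in this assay (a 1.5-fold higher number from compound 3 to compound 4 (0.17 log units; within the scatter)), so this position tolerates both groups so far. The 4-chlorophenyl urea also cannot be separated from the 3-methylphenyl urea (a 1.3-fold lower number from compound 2 to compound 4 (0.10 log units; within the scatter)), while it remains clearly weaker than the 2-methylphenyl urea (a 3.4-fold higher number from compound 1 to compound 4 (0.54 log units; beyond the scatter)). No supporting data are available to explain these numbers.

The compounds shown leave open whether an amine or a carboxylic acid at this place would shift the number beyond the scatter. They also leave open whether a 2-chlorophenyl group would match the 2-methylphenyl group of compound 1.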